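Chloro in place of fluoro on two related cores

A few compounds are considered here, and "the series" means these few. Any claim that something is new, unique, unknown or untested is made for them only; others in the source may bear on it.

Of the compounds shown here, three have been measured, and a fourth awaits its turn. Compound 1, `COc1ccccc1S(=O)(=O)/C=C/c1ncccc1F`, and compound 2, `COc1ccccc1S(=O)(=O)/C=C/c1ncccc1Cl`, share one core. Compound 3, `COc1cccc(S(=O)(=O)/C=C/c2ncccc2F)c1`, is built from the same atoms joined differently, and the difference between the two cores is not broken down here. In an ADME assay on BV-2 cells (Mus musculus) for cytotoxicity, with a stated time of 24 h, tested at 50 uM (a higher number here means a weaker effect of the compound at the concentration tested, a lower number a stronger effect), compound 1 gives 99.2%, compound 2 gives 100%, and compound 3 gives 97.4%. The change from compound 1 to compound 2 is chloro in place of fluoro on an aromatic carbon; the measured step was a number 0.8 percentage points higher from compound 1 to compound 2 (within the scatter). Compound 4, `COc1cccc(S(=O)(=O)/C=C/c2ncccc2Cl)c1`, is not yet measured. The change from compound 3 to compound 4 is chloro in place of fluoro on an aromatic carbon, the same change at the same place as before. The step is expected to be a number 1.1 percentage points higher from compound 3 to compound 4 (within the scatter) in this assay, because the earlier step of the same change was a number 0.8 percentage points higher from compound 1 to compound 2 (within the scatter). Compound 4 is therefore estimated to give 98.5% in this assay, with a likely range from 93% to 100%.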

Compound 4, a percentage reported as activity, at one concentration (the size of the read-out at that concentration, not a potency): 82.2%
For compound 4 the middle estimate is 16.3 percentage points above the measured one; measured number outside the range, below it.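

In this assay, chloro in place of fluoro on an aromatic carbon behaved differently on the second core, giving a number 15.2 percentage points lower from compound 3 to compound 4 (beyond the scatter). The two steps of this one change do not agree, so the step measured on the first core did not carry over to the second: the same change on two cores in this assay, a number 0.8 percentage points higher (within the scatter) from compound 1 to compound 2 and a number 15.2 percentage points lower (beyond the scatter) from compound 3 to compound 4, 16 percentage points apart, beyond the scatter of two such steps

This shows that, for these two pairs of compounds, the outcome of the change depends on the core around it, and a step seen on one core is a poor guide to the other. It does not show why the cores differ, and two pairs cannot tell how the same change would behave on any further core.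

The compounds shown carry only fluoro or chloro at this place, so it remains open whether a bromo group, a methyl group or an amine there would follow either step. Each reading also comes from a single concentration, which leaves open how the effect of compound 4 changes with dose.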